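This account rests on a few compounds, and the source may have more. Where it says the series, first, only, none or still open, it means among the compounds named here.

In a functional assay on the whole organism for inhibition, with Rattus norvegicus as the target (on this read-out lower numbers stand for an effect already at smaller amounts and higher numbers for an effect only at larger amounts of compound), compound 1 (`CCc1ccccc1CC(C)(Oc1ccc(C(C)C)cc1)C(=O)O`) gives 5 mg/kg as its half-maximal dose, and compound 2 (`CC(C)c1ccc(OC(C)(Cc2ccccc2-c2ccccc2)C(=O)O)cc1`) gives 10 mg/kg on the same read-out. These two numbers lie within the usual scatter of each other, so compound 1 stands level with compound 2 as far as the data can tell. Compound 3 (`CC(C)c1ccc(OC(C)(Cc2ccc(Cl)c(Cl)c2)C(=O)O)cc1`) has not yet been measured. It differs from compound 1 as follows (3,4-dichlorophenyl in place of 2-ethylphenyl on a saturated chain carbon, two bonds along the chain from a carbonyl carbon and an oxygen on an aromatic ring), with 3,4-dichlorophenyl in place of 2-ethylphenyl on a saturated chain carbon, two bonds along the chain from a carbonyl carbon and an oxygen on an aromatic ring. Going by the values given here, the only measured step that touches this group is phenyl in place of ethyl (a 2.0-fold higher number from compound 1 to compound 2 (0.30 log units; within the scatter)), and it stays within the scatter. Among the compounds with values here, no measured compound carries chlorine, so the data give no direct guide to this change. Going by that single step, no shift beyond the scatter is expected in this assay and no firm direction can be given. The estimated step is small (a 1.4-fold higher number from compound 1 to compound 3 (0.15 log units; within the scatter)) and lies within the scatter. Compound 3 is expected at 7 mg/kg with an estimated range from 2 mg/kg to 25 mg/kg on this measure.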

Compound 3, dose for half-maximal effect: 5 mg/kg
Compound 3: middle estimate off by 1.4-fold (0.15 log units), on the high side; the range from low to high includes it.
By their numbers in this assay, from the lowest: compounds 1, 3 and 2 (each within the scatter of the next).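

In this assay, putting 3,4-dichlorophenyl in place of 2-ethylphenyl on the saturated chain carbon, two bonds along the chain from a carbonyl carbon and an oxygen on an aromatic ring, gives no change at the digits printed from compound 1 to compound 3 (within the scatter). The earlier pair had shown only the exchange of ethyl for phenyl on the aromatic ring, with a 2.0-fold higher number from compound 1 to compound 2 (0.30 log units; within the scatter); this new step replaces the whole 2-ethylphenyl group and brings in chlorine for the first time, and it too stays within the scatter, so none of the listed changes at this place has yet moved the dose beyond what repeated measurements would give. Nothing among the data speaks to why the read-out stays level across these two different groups.

The compounds shown leave open whether any group at this place would give a step beyond the scatter, for instance a pyridine ring, a methoxyphenyl group or an aminophenyl group in place of the substituted phenyl. They also leave open whether each chlorine of the 3,4-dichlorophenyl group matters on its own, and what an amide in place of the carboxylic acid would do in this assay.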